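The compounds below may be only part of what the source reports. "The series", "measured", "known", "first", "only" and "open" are said of these compounds alone.

Within the data shown here, compound 1 `COC(=O)c1ccccc1-c1ccc(CCc2ncc(CC(C)(C)C)n2CC(=O)O)cc1` gives 694 nM in an assay on cells for agonist activity at Bombesin receptor subtype-3 (Mus musculus), read by HTRF and inositol phosphate accumulation, with a stated time of 1 h (a higher number here means that more compound is needed for the effect, a lower number that less compound is needed), the lowest of the two numbers measured so far, with compound 2 as its nearest neighbour. Compound 2 `CC(C)(C)Cc1cnc(CCc2ccc(-c3ccccc3C(=O)O)cc2)n1CC(=O)O` gives 1270 nM, and the step of a 1.8-fold higher number from compound 1 to compound 2 (0.26 log units; within the scatter) concerns hydrogen in place of methyl on an oxygen next to a carbonyl group. Compound 3 `COC(=O)c1ccccc1-c1ccc(CCc2ncc(CC(C)(C)C)[nH]2)cc1` differs from compound 1 by hydrogen in place of carboxymethyl on an aromatic nitrogen. Among the measured compounds shown here, that change sits at a different place from the one measured step, which stayed within the scatter, so no measured step bears on it directly and the outcome is open. The number for compound 3 is therefore expected to move by a 2.9-fold higher number from compound 1 to compound 3 (0.46 log units; beyond the scatter), most likely upward, with a wide range. Compound 3 is estimated at 2000 nM, between 400 nM and 10000 nM.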

Compound 3, half-maximal effective concentration: 498 nM
Compound 3: middle estimate off by 4.0-fold (0.60 log units), on the high side; the range from low to high includes it.
By their numbers in this assay, from the lowest: compounds 3, 1 and 2 (each within the scatter of the next, the first and the last beyond it).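

Replacing the carboxymethyl on the aromatic nitrogen with hydrogen gives a 1.4-fold lower number from compound 1 to compound 3 (0.14 log units; within the scatter) in this assay. The whole group can therefore go without the number leaving the scatter, at least on the core of compound 1, which carries the methyl ester. Nothing available explains why this exchange leaves the number within the scatter.

Still open, as far as these compounds go, is whether a simple methyl, a longer chain or an amine-bearing chain on this nitrogen would move the number beyond the scatter. From the compounds shown here alone, whether hydrogen here behaves the same way with the carboxylic acid of compound 2 also remains open.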